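Benzofuran Amide in Place of Naphthalene: Expected Cytotoxicity

A few compounds are considered here, and "the series" means these few. Any claim that something is new, unique, unknown or untested is made for them only; others in the source may bear on it.

Three amides on a shared core have been measured. Compound 1 `COc1ccc(C(=O)NC[C@H]2c3[nH]c4ccccc4c3C[C@H]3[C@H]4c5[nH]c6ccccc6c5C[C@@H]([C@H](C#N)N23)N4C)cc1` gives 320 nM in a functional assay on A2780 cells (Homo sapiens) for cytotoxicity, read by MTT assay, with a stated time of 72 h; on this read-out lower numbers stand for stronger inhibition and higher numbers for weaker inhibition. Compound 2 `CN1[C@@H]2c3[nH]c4ccccc4c3C[C@H]1[C@H](C#N)N1[C@@H](CNC(=O)c3cccc4c3CCCC4)c3[nH]c4ccccc4c3C[C@@H]21` gives 810 nM. Compound 3 `CN1[C@@H]2c3[nH]c4ccccc4c3C[C@H]1[C@H](C#N)N1[C@@H](CNC(=O)c3ccc4ccccc4c3)c3[nH]c4ccccc4c3C[C@@H]21` gives 1030 nM, the highest number of the three, within the scatter of compound 2 and separated beyond the scatter only from compound 1. The change to compound 4 `CN1[C@@H]2c3[nH]c4ccccc4c3C[C@H]1[C@H](C#N)N1[C@@H](CNC(=O)c3cc4ccccc4o3)c3[nH]c4ccccc4c3C[C@@H]21` is 1-benzofuran-2-yl in place of naphthalen-2-yl on a carbonyl carbon. For the measured compounds named here, no measured step covers this exact swap; the related steps of a 2.5-fold higher number from compound 1 to compound 2 (0.40 log units; beyond the scatter) and a 3.2-fold higher number from compound 1 to compound 3 (0.51 log units; beyond the scatter) were modest, while a 1.3-fold higher number from compound 2 to compound 3 (0.10 log units; within the scatter) lay within the scatter, so exchanging one bicyclic aryl for another has so far barely moved the number. The step is expected to be a 1.3-fold lower number from compound 3 to compound 4 (0.11 log units; within the scatter), within the scatter. Compound 4 is therefore estimated at 800 nM, between 350 nM and 2000 nM.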

Compound 4, half-maximal inhibitory concentration: 230 nM
Compound 4: middle estimate off by 3.5-fold (0.54 log units), on the high side, and the stated range ends above it.
By their numbers in this assay, from the lowest: compounds 4 and 1 (each within the scatter of the next); then compounds 2 and 3 (each within the scatter of the next).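

In this assay the group on this carbonyl carbon turns out to matter among bicyclic aryls: 1-benzofuran-2-yl brings a 4.5-fold lower number from compound 3 to compound 4 (0.65 log units; beyond the scatter) and also a 3.5-fold lower number from compound 2 to compound 4 (0.55 log units; beyond the scatter) even though the earlier swap between two bicyclic groups stayed within the scatter. With a 1.4-fold lower number from compound 1 to compound 4 (0.14 log units; within the scatter) as the remaining step, compound 4 and compound 1 cannot be told apart. No evidence at hand accounts for this difference.

The compounds shown leave open which part of 1-benzofuran-2-yl goes with the lower number. A 1-benzothiophen-2-yl or furan-2-yl group on the same carbonyl carbon would test this.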